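The source may report more compounds than this note shows. Statements on the series, on what has been measured and on what is new or still open speak of the compounds shown alone.

Values in a functional assay on HCT-8 cells (Homo sapiens) for cytotoxicity; a lower number here means that less compound is needed, a higher number that more compound is needed for the effect:
compound 1 `COC1=C(C)C(=O)/C(=C(O)/C=C/c2ccc(Br)cc2)C(=O)C1(C)C`: 7.4 ug/mL
compound 2 `COC1=C(C)C(=O)/C(=C(O)/C=C/c2ccc(OC)cc2)C(=O)C1(C)C`: 5.6 ug/mL
compound 3 `COC1=C(C)C(=O)/C(=C(O)/C=C/c2ccccc2C)C(=O)C1(C)C`: 4 ug/mL

These compounds share one core and differ only in the aromatic group on a double-bonded chain carbon bound to a double-bonded chain carbon. Compound 3, at 4 ug/mL, stands within the scatter of both other compounds, so the numbers set no order among the three.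

The next compound is compound 4 `COC1=C(C)C(=O)/C(=C(O)/C=C/c2cccs2)C(=O)C1(C)C`, in which thiophen-2-yl comes in place of the 2-methylphenyl of compound 3 at that same place: thiophen-2-yl in place of 2-methylphenyl on a double-bonded chain carbon bound to a double-bonded chain carbon.

Two measured steps exchange the aromatic group at this place: a 1.9-fold lower number from compound 1 to compound 3 (0.27 log units; within the scatter) and a 1.4-fold lower number from compound 2 to compound 3 (0.15 log units; within the scatter). A third, a 1.3-fold lower number from compound 1 to compound 2 (0.12 log units; within the scatter), exchanges only the group on the aromatic ring. All three stay within the scatter. Within the data shown here, no measured compound carries a five-membered aromatic ring, however, so the data do not test thiophen-2-yl directly.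

A step beyond the scatter in this assay is therefore not expected, and the data favour no direction. The estimated step, a 1.3-fold higher number from compound 3 to compound 4 (0.10 log units; within the scatter), stays inside the scatter. The expected value for compound 4 is 5 ug/mL, with an estimated range from 2.5 ug/mL to 10 ug/mL.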

Compound 4, concentration for half-maximal effect: 8.6 ug/mL
The estimate for compound 4 lay 1.7-fold (0.24 log units) below the measured number; the measured number falls inside the stated range.
By their numbers in this assay, from the lowest: compounds 3, 2, 1 and 4 (each within the scatter of the next, the first and the last beyond it).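

In this assay, among these compounds, exchanging the aromatic group on a double-bonded chain carbon bound to a double-bonded chain carbon now gives a first step beyond the scatter (a 2.2-fold higher number from compound 3 to compound 4 (0.33 log units; beyond the scatter)), a modest one, so this place does respond to the group it carries, at least for this one pair. Thiophen-2-yl does not separate compound 4 from the other two compounds, since both a 1.5-fold higher number from compound 2 to compound 4 (0.19 log units; within the scatter) and a 1.2-fold higher number from compound 1 to compound 4 (0.07 log units; within the scatter) stay within the scatter, which means that the five-membered aromatic ring sets compound 4 apart only from compound 3. Among the compounds shown here, nothing available gives a reason for the one step beyond the scatter.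

The compounds shown leave open whether that step belongs to the entering thiophen-2-yl or to the leaving 2-methylphenyl, a question that an unsubstituted phenyl or a furan-2-yl at the same place would bear on. They also leave open how this place would respond to an aromatic ring carrying an amine or a carboxylic acid, or to a longer chain in place of the aromatic group.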